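Swapping an imidazolyl for a butyl chain in a chalcone

The source may report more compounds than this note shows. Statements on the series, on what has been measured and on what is new or still open speak of the compounds shown alone.

Measured compounds in an ADME assay on THP-1 cells (Homo sapiens) for cytotoxicity, read by resazurin assay, with a stated time of 72 h; a higher number here means that more compound is tolerated, a lower number that less compound is tolerated:
compound 1 `CC(C)(C)c1ccc(C(=O)/C=C/c2ccco2)cc1`: > 50000 nM
compound 2 `O=C(/C=C/c1ccc([N+](=O)[O-])s1)c1ccc(-n2ccnc2)cc1`: 23400 nM
compound 3 `COc1ccc(/C=C/C(=O)c2cccc(I)c2)cc1`: > 50000 nM

Compound 2 is the only one of the three whose value in this assay is an actual number, at 23400 nM. The value of compound 1 is a limit of the assay, not a number. The value of compound 3 is likewise a limit, and both of them sit at the limit of > 50000 nM in this assay, at which 2 of the 3 values shown sit, so compound 2 tolerates less compound than either of those two, as far as a limit allows a comparison.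

Compound 4 `CCCCc1ccc(C(=O)/C=C/c2ccc([N+](=O)[O-])s2)cc1` differs from compound 2 in one place: butyl in place of 1H-imidazol-1-yl on an aromatic carbon. For the measured compounds named here, no step between two measured compounds separates these two groups, so the size of the change in this assay is open. Going by the values given here, two of the three measured compounds rest at the limit, which makes a move toward it plausible, but the data give no step to weigh. The expected step from compound 2 to compound 4 is a 1.5-fold higher number from compound 2 to compound 4 (0.17 log units; within the scatter). For compound 4 the expected value is 35000 nM, between 12000 nM and 100000 nM.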

Compound 4, half-maximal cytotoxic concentration: 17100 nM
Beside the measured number, compound 4's estimate is 2.0-fold (0.31 log units) above it; measured number inside the range.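

In this assay, for the compounds shown here, butyl in place of 1H-imidazol-1-yl on an aromatic carbon, para to a large group, gives the one step that can be read at this position: a 1.4-fold lower number from compound 2 to compound 4 (0.14 log units; within the scatter). Exchanging a five-membered aromatic ring with 2 hydrogen-bond acceptors for a chain with no ring and no acceptors therefore leaves the two numbers within the scatter of each other, so this position tolerates the change without a readable shift. Compound 4 also yields an actual number rather than a limit of the assay: the limit of > 50000 nM in this assay, at which 2 of the 4 values shown sit.

The compounds shown leave open whether a group of another kind on this carbon, such as an amine, a carboxylic acid or a longer alkyl chain, would stay as close to compound 2. They also leave open whether the same exchange would give a similar step on the core of compound 1 or compound 3.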